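Amine tail variation and mouse exposure after subcutaneous dosing

The compounds below may be only part of what the source reports. "The series", "measured", "known", "first", "only" and "open" are said of these compounds alone.

Measured compounds:
- compound 1, `Cc1ccccc1C(=O)Nc1ccc(C(=O)N2CCCC(NCCCc3ccncc3)c3cc(Cl)ccc32)c(C)c1`, giving 565 ng.h/mL in an ADME assay on the whole organism (Mus musculus, strain C57BL/6) for pharmacokinetics, read by LC-MS, at a dose of 2 mg/kg by the subcutaneous route; a higher number here means more compound in the circulation at the dose given, a lower number less compound in the circulation
- compound 2, `Cc1ccccc1C(=O)Nc1ccc(C(=O)N2CCCC(NCCCN3CCN(C)CC3)c3cc(Cl)ccc32)c(C)c1`, giving 588 ng.h/mL in this assay

Compound 2 and compound 1 lie within the scatter of each other on these two numbers, so neither can be placed above the other. Compound 3, `CCN(CC)CCCNC1CCCN(C(=O)c2ccc(NC(=O)c3ccccc3C)cc2C)c2ccc(Cl)cc21`, differs from compound 2 in one place: diethylamino in place of 4-methylpiperazin-1-yl on a saturated chain carbon, three bonds along the chain from an amine nitrogen. For the measured compounds named here, the only measured step that bears on this is the one at the same place on the chain, a 1.0-fold higher number from compound 1 to compound 2 (0.02 log units; within the scatter), where exchanging one terminal group for another left the exposure where it was. Going by the values given here, two points are too few for a pattern, but nothing measured so far gives a reason to expect the terminal group on this chain to move the exposure in this assay beyond the scatter. The change from compound 2 to compound 3 is therefore expected to read a 1.0-fold lower number from compound 2 to compound 3 (0.01 log units; within the scatter). Compound 3 is estimated to give 580 ng.h/mL in this assay, with a range from 260 ng.h/mL to 1300 ng.h/mL.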

Compound 3, area under the concentration-time curve: 527 ng.h/mL
Estimate against measurement, compound 3: 1.1-fold (0.04 log units) above, and the stated range covers the measured number.
By their numbers in this assay, from the lowest: compounds 3, 1 and 2 (each within the scatter of the next).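

With diethylamino on a saturated chain carbon, three bonds along the chain from an amine nitrogen, this assay gives a 1.1-fold lower number from compound 2 to compound 3 (0.05 log units; within the scatter), and the comparison with the pyridin-4-yl terminus gives a 1.1-fold lower number from compound 1 to compound 3 (0.03 log units; within the scatter). Compound 1 and compound 2 both carry a ring at this end of the chain, whereas diethylamino has none, so the three compounds show that, among these groups, a terminal ring is not required for the reading to stay within the scatter. No measurement of any other property bears on why the three readings sit together.

The compounds shown leave open whether the same holds for a terminal group of a different kind, such as a carboxylic acid, a hydroxyl or an unsubstituted primary amine, and whether a longer or shorter chain between the amine nitrogen and the terminal group would read the same. They also leave open whether this insensitivity to the terminal group extends to other doses or routes, as all three readings come from one dose and one route on the shared core.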